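The compounds below may be only part of what the source reports. "The series", "measured", "known", "first", "only" and "open" are said of these compounds alone.

Measured compounds in an assay for inhibition of prostacyclin synthase (Homo sapiens), using microsomes; on this read-out higher numbers stand for weaker inhibition and lower numbers for stronger inhibition:
Compound 1 `CC(C)(Oc1ccccc1)C1OCC(C/C=C\CCC(=O)O)C(c2cccnc2)O1` gives 75000 nM.
Compound 2 `COc1ccc(OC(C)(C)C2OCC(C/C=C\CCC(=O)O)C(c3cccnc3)O2)cc1` gives only a limit of the assay, > 100000 nM.
Compound 3 `Cc1ccc(OC(C)(C)C2OCC(C/C=C\CCC(=O)O)C(c3cccnc3)O2)cc1` gives 25000 nM.

Among the two numbers that were actually reached, compound 3 holds the lower one, and its nearest neighbour is compound 1, which shows a 3.0-fold lower number from compound 1 to compound 3 (0.48 log units; beyond the scatter). Compound 2 is represented by a limit alone; this is recorded as the limit of > 100000 nM in this assay, at which 1 of the 3 values shown sits. Against that limit compound 3 shows an at least 4.0-fold lower number from compound 2 to compound 3 (0.60 log units; beyond the scatter).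

Compound 4 `CC(C)(Oc1ccccc1F)C1OCC(C/C=C\CCC(=O)O)C(c2cccnc2)O1` differs from compound 3 in one place: 2-fluorophenyl in place of 4-methylphenyl on an oxygen on a saturated carbon. Within the data shown here, none of the measured steps changes the phenyl group in exactly this way. Among the measured compounds shown here, the steps that bear on it concern substitution on the same phenyl ring: a methyl on that ring gave a 3.0-fold lower number from compound 1 to compound 3 (0.48 log units; beyond the scatter), while a methoxy gave an at least 1.3-fold higher number from compound 1 to compound 2 (0.12 log units; that floor lies within the scatter). For the measured compounds named here, compound 4 loses the methyl that helped compound 3 and gains a fluorine in a different position of the ring, for which no measured step exists. The expectation is therefore that compound 4 falls back toward compound 1, that is a 2.4-fold higher number from compound 3 to compound 4 (0.38 log units; beyond the scatter) in this assay. Compound 4 is estimated at 60000 nM, with a range from 20000 nM to 150000 nM.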

Compound 4, half-maximal inhibitory concentration: < 1000 nM
Compound 4: only a limit was reported (the forecaster's own chance of this, stated with the estimate: 25%); middle value at least 60-fold (1.77 log units) from the limit.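

Compound 4 is recorded only as a limit: the limit of < 1000 nM in this assay, at which 1 of the 4 values shown sits. Adding a fluorine to the phenyl group gives an at least 75-fold lower number from compound 1 to compound 4 (1.87 log units; beyond the scatter) in this assay, whereas adding a methyl to that group gave only a 3.0-fold lower number from compound 1 to compound 3 (0.48 log units; beyond the scatter). Among these compounds, the 2-fluorophenyl group also gives an at least 25-fold lower number from compound 3 to compound 4 (1.39 log units; beyond the scatter) when it takes the place of 4-methylphenyl and an at least 100-fold lower number from compound 2 to compound 4 (2.00 log units; beyond the scatter) when it takes the place of 4-methoxyphenyl, so this group on the oxygen, which the earlier compounds showed moving the number only modestly at most, can carry a large change.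

With compound 4 standing only as a limit, the compounds shown do not tell how far its number actually lies beyond that limit, and so how large these steps really are. They also leave open whether the large step belongs to fluorine as such, or would also follow from a chlorine or a methyl in its place, or from a fluorine on another carbon of the same ring.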